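The source may hold more compounds than are shown below. What is called first, only, known or untested is meant among the compounds shown, and "the series" means these compounds.

The three measured compounds share one core and differ only in the group placed on a saturated chain carbon bound to an oxygen on an aromatic ring. Compound 1, `COc1cccc(OC)c1OCCNCCOc1ccccc1OCc1ccccc1Cl`, gives 0.251 nM in an assay on CHO cells for displacement of a labelled ligand from Alpha-1D adrenergic receptor (Homo sapiens); on this read-out higher numbers stand for weaker inhibition and lower numbers for stronger inhibition. Compound 2, `COc1cccc(OC)c1OCCNCCOc1ccccc1OCc1ccc(Cl)cc1`, gives 0.0316 nM, and compound 3, `COc1ccccc1COc1ccccc1OCCNCCOc1c(OC)cccc1OC`, gives 2 nM. Compound 1 therefore stands second highest of the three numbers: its nearest neighbour is compound 2, reached by a 7.9-fold lower number from compound 1 to compound 2 (0.90 log units; beyond the scatter), and its furthest is compound 3, reached by an 8.0-fold higher number from compound 1 to compound 3 (0.90 log units; beyond the scatter).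

Compound 4, `COc1ccc(COc2ccccc2OCCNCCOc2c(OC)cccc2OC)cc1`, has not yet been measured. Relative to compound 1 it carries 4-methoxyphenyl in place of 2-chlorophenyl on a saturated chain carbon bound to an oxygen on an aromatic ring. Within the data shown here, two measured steps bear on this change. The shift of the chlorine from the 2-chlorophenyl to the 4-chlorophenyl arrangement gave a 7.9-fold lower number from compound 1 to compound 2 (0.90 log units; beyond the scatter), a modest fall in the number. The exchange of chloro for methoxy on the aromatic carbon gave an 8.0-fold higher number from compound 1 to compound 3 (0.90 log units; beyond the scatter), a modest rise. Compound 4 combines both moves, and if the two effects simply add they roughly cancel, so for compound 4 a step of about a 1.2-fold higher number from compound 1 to compound 4 (0.08 log units; within the scatter) is expected, with no clear direction beyond the scatter. Compound 4 is thus estimated at 0.3 nM, within a range from 0.06 nM to 1.5 nM.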

Compound 4, inhibition constant: 0.1 nM
Compound 4: the middle estimate sits 3.0-fold (0.48 log units) above what was measured, within the range that was stated.
By their numbers in this assay, from the lowest: compound 2; then compound 4; then compound 1; then compound 3.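

Moving the methoxy group from the 2-methoxyphenyl to the 4-methoxyphenyl arrangement gives a 20-fold lower number from compound 3 to compound 4 (1.30 log units; beyond the scatter), so the fall seen earlier between the two chlorophenyl compounds is now matched in direction by a second pair, and among these four compounds no pair goes against it. The 4-methoxyphenyl group also improves on the 2-chlorophenyl group, with a 2.5-fold lower number from compound 1 to compound 4 (0.40 log units; beyond the scatter), which shows that at this position the arrangement of the substituent outweighs the exchange of chloro for methoxy in this pair, where simple addition of the two earlier steps had suggested that they would cancel. The exchange of chloro for methoxy can now be read on a second pair, with a 3.2-fold higher number from compound 2 to compound 4 (0.50 log units; beyond the scatter), and it raises the number on both: the same change on two cores in this assay, an 8.0-fold higher number (0.90 log units; beyond the scatter) from compound 1 to compound 3 and a 3.2-fold higher number (0.50 log units; beyond the scatter) from compound 2 to compound 4, 2.5-fold (0.40 log units) apart, within the scatter of two such steps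

The compounds shown carry only chloro and methoxy on this phenyl ring, so they leave open how a plain phenyl, or a phenyl bearing a fluoro or a hydroxy group, would stand in this assay. They also leave open whether this order of the four compounds would hold at any other receptor.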